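The compounds below may be only part of what the source reports. "The series", "measured", "known", "first", "only" and "open" are said of these compounds alone.

Working notes on a series of bivalent acylguanidines measured in an in vitro functional assay on Sf9 cells for agonist activity at histamine H2 receptor (Homo sapiens); a lower number here means a smaller maximal response, a higher number a larger maximal response. Compound 1, `Cc1nc(N)sc1CCCN/C(N)=N/C(=O)CCCCCCCCC(=O)/N=C(\N)NCCCc1sc(N)nc1C`, gives 0.53. Compound 2, `Cc1nc(N)sc1CCCN/C(N)=N/C(=O)CCCCCCCCCCC(=O)/N=C(\N)NCCCc1sc(N)nc1C`, gives 0.46. Compound 3, `N/C(=N\C(=O)CCCCCCCCC(=O)/N=C(\N)NCCCc1cnc(N)s1)NCCCc1cnc(N)s1`, gives 0.75, the highest of the three numbers; its nearest neighbour is compound 1, lower by a margin beyond the scatter, and the furthest is compound 2, lower by a larger margin, also beyond the scatter.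

The next compound, compound 4, `Cc1nc(N)sc1CCCN/C(N)=N/C(=O)CCCCCCCCC(=O)/N=C(\N)NCCCc1cnc(N)s1`, has not yet been measured. It differs from compound 3 in one place: methyl in place of hydrogen on an aromatic carbon. Compound 3 carries no such methyl on either ring, compound 1 carries one on both; compound 4 carries one on a single ring.

Among the compounds with values here, no single-change pair among the measured compounds fixes the size of this step. The expectation is that compound 4 sits between compound 3 and compound 1, so a downward step from compound 3 to compound 4 of a number 0.11 lower from compound 3 to compound 4 (beyond the scatter) is expected, close to the edge of the scatter. Compound 4 is expected to give 0.64 in this assay, with a likely range from 0.5 to 0.8.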

Compound 4, intrinsic activity: the largest response reached, as a fraction of the reference agonist's: 0.75
For compound 4 the middle estimate is 0.11 below the measured one, and the stated range covers the measured number.
By their numbers in this assay, from the lowest: compounds 2 and 1 (each within the scatter of the next); then compounds 3 and 4 (each within the scatter of the next).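

In this assay, one methyl on an aromatic carbon, next to the ring nitrogen, on one of the two rings, costs nothing in maximal response, with no change at the digits printed from compound 3 to compound 4 (within the scatter). Hydrogen in place of methyl on one ring of compound 1 does change the response, with a number 0.22 higher from compound 1 to compound 4 (beyond the scatter), so the effect of this position depends on whether the other ring also carries a methyl: the drop appears only when both rings do. Nothing measured here explains this dependence.

On these data alone, it remains open whether the position tolerates a group larger than methyl, such as ethyl, or a chlorine atom, on a single ring. As far as these compounds go, the same one-ring methyl also remains untested on the longer chain of compound 2.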